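This account rests on a few compounds, and the source may have more. Where it says the series, first, only, none or still open, it means among the compounds named here.

Compound 1 `Oc1ccc(NC(=S)Nc2ccc3[nH]ccc3c2)cc1` gives 17000 nM in an assay on cells for inhibition of Amine oxidase [flavin-containing] B (Homo sapiens), read by spectrophotometry; a lower number here means a stronger inhibitor, a higher number a weaker inhibitor.
Compound 2 `Oc1ccc(NC(=S)Nc2ccc3[nH]ccc3c2)cc1Cl` gives 8600 nM in this assay.

Both share one core. In this assay compound 2 gives 8600 nM and compound 1 gives 17000 nM; the step of a 2.0-fold lower number from compound 1 to compound 2 (0.30 log units; within the scatter) lies within the scatter, so the two stand side by side. Compound 3 `COC(=O)c1cc(NC(=S)Nc2ccc3[nH]ccc3c2)ccc1O` differs from compound 2 by methoxycarbonyl in place of chloro on an aromatic carbon. For the measured compounds named here, only that single measured step touches the same position, and it was small; no measured step brings in a methoxycarbonyl group. The step expected for compound 3 is a 1.4-fold higher number from compound 2 to compound 3 (0.14 log units; within the scatter), essentially none beyond the scatter. The estimated value for compound 3 is 12000 nM, with a range from 4000 nM to 40000 nM.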

Compound 3, half-maximal inhibitory concentration: 31000 nM
Beside the measured number, compound 3's estimate is 2.6-fold (0.41 log units) below it; low and high end bracket the measured number.
By their numbers in this assay, from the lowest: compounds 2, 1 and 3 (each within the scatter of the next, the first and the last beyond it).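

Placed ortho to a hydroxy group, methoxycarbonyl gives the first step beyond the scatter in this assay, a modest one (a 3.6-fold higher number from compound 2 to compound 3 (0.56 log units; beyond the scatter)). Set against hydrogen, the same group gives a step within the scatter (a 1.8-fold higher number from compound 1 to compound 3 (0.26 log units; within the scatter)), so only the comparison with chloro separates the compounds at this position. Nothing available explains this result.

Going by these compounds, it remains open whether a carboxylic acid or an amine at this position would stay level with hydrogen. On these data alone, whether any group here can give a large step also remains open.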